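Swapping an Aryl Substituent on a Nitrile Core

This account rests on a few compounds, and the source may have more. Where it says the series, first, only, none or still open, it means among the compounds named here.

Measured so far in a physicochemical assay for lipophilicity, read by HPLC, at pH 7.5; on this read-out lower numbers stand for lower lipophilicity and higher numbers for higher lipophilicity:
- compound 1 `CC[C@@H](Nc1c(C#N)c(-c2ccc(-c3cccc(Cl)c3OC)cc2)nc2cnccc12)C(N)=O` gives 3.1
- compound 2 `CC(C)(CC(N)=O)c1c(C#N)c(-c2ccc(Br)cc2)nc2cnccc12` gives 2.1
- compound 3 `CCOc1ccccc1-c1ccc(-c2nc3cnccc3c(N[C@H](CC)C(=O)O)c2C#N)cc1` gives 2.1

Among these three, compound 1 stands highest, with compound 2 and compound 3 each a full step lower, beyond the usual scatter. Among the measured compounds shown here, no pair of measured compounds differs in just one place, so no single step has been measured.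

Compound 4 `CC[C@@H](Nc1c(C#N)c(-c2ccc(-c3ccccc3C(F)(F)F)cc2)nc2cnccc12)C(N)=O` has not yet been measured. It differs from compound 1 in one spot: 2-(trifluoromethyl)phenyl in place of 3-chloro-2-methoxyphenyl on an aromatic carbon.

Both groups are a single aromatic ring carrying small substituents, so the expected step from compound 1 to compound 4 is small, a number 0.10 log units higher from compound 1 to compound 4 (within the scatter), not clearly beyond the scatter. Compound 4 is therefore estimated at 3.2, within 2.7 to 3.7, close to the value of compound 1.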

Compound 4, distribution coefficient: 3.1
For compound 4 the middle estimate is 0.10 log units above the measured one, and the stated range covers the measured number.
By their numbers in this assay, from the lowest: compounds 2 and 3 (each within the scatter of the next); then compounds 1 and 4 (each within the scatter of the next).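

In this assay, among the compounds shown here, putting 2-(trifluoromethyl)phenyl in place of 3-chloro-2-methoxyphenyl, para to a large group, gives no change at the digits printed from compound 1 to compound 4 (within the scatter) and is the first single change that can be read in this set. At this position, then, an aryl group with methoxy and chloro substituents and one with a trifluoromethyl substituent cannot be told apart on this read-out. Nothing available explains this match.

Only these two aryl groups are compared here. An amine or a carboxylic acid on this ring could behave differently, and so could an unsubstituted phenyl.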